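This account rests on a few compounds, and the source may have more. Where it says the series, first, only, none or still open, it means among the compounds named here.

Measured compounds:
- compound 1 `O=C1c2ccccc2C(=O)N1C/C=C\Cn1cc(C#Cc2ccc(Br)cc2)c(=O)[nH]c1=O`: in an ADME assay on WI-38 cells (Homo sapiens) for cytotoxicity, read by MTT assay, with a stated time of 3 days (a lower number here means a stronger inhibitor, a higher number a weaker inhibitor), compound 1 gives 47000 nM
- compound 3 `CCCCc1ccc(C#Cc2cn(C/C=C/CN3C(=O)c4ccccc4C3=O)c(=O)[nH]c2=O)cc1`: in this assay compound 3 gives 40000 nM
- compound 2 `CCCCCc1ccc(C#Cc2cn(C/C=C\CN3C(=O)c4ccccc4C3=O)c(=O)[nH]c2=O)cc1`: in this assay compound 2 reaches only a limit, > 100000 nM

Compound 3 and compound 1 give numbers that lie within the usual scatter of each other, so neither can be called weaker or stronger. Compound 4 `CCCCc1ccc(C#Cc2cn(C/C=C\CN3C(=O)c4ccccc4C3=O)c(=O)[nH]c2=O)cc1` differs from compound 3 only in this way: the two compounds have the same atoms and bonds and differ only in configuration as drawn: 1 of 1 stereo elements differ; a double bond is drawn E in compound 3 and Z in compound 4. For the measured compounds named here, no measured pair differs solely in double-bond geometry. Going by the values given here, the one measured step, an at least 2.1-fold higher number from compound 1 to compound 2 (0.32 log units; beyond the scatter), concerns the chain on the aromatic ring instead, and compound 2 sits at the limit of > 100000 nM in this assay, at which 1 of the 3 values shown sits. Compound 2 carries the same Z geometry as compound 4 with a chain one carbon longer, which suggests a higher number for the Z form. For the step from compound 3 to compound 4 a modest rise is expected, a 1.6-fold higher number from compound 3 to compound 4 (0.21 log units; within the scatter). Compound 4 is therefore estimated at 65000 nM, between 25000 nM and 150000 nM.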

Compound 4, half-maximal inhibitory concentration: 17000 nM
The estimate for compound 4 lay 3.8-fold (0.58 log units) above the measured number, and the stated range ends above it.
By their numbers in this assay, from the lowest: compound 4; then compounds 3 and 1 (each within the scatter of the next). At a limit, above all of these: compound 2.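

Double-bond geometry alone changes the result in this assay, with a 2.4-fold lower number from compound 3 to compound 4 (0.37 log units; beyond the scatter), and this step can be placed on that bond because of the following: the fact that compounds 3 and 4 differ only in the configuration as drawn. With the Z double bond kept, the group on the aromatic ring also counts, as seen in an at least 5.8-fold lower number from compound 2 to compound 4 (0.76 log units; beyond the scatter) and in a 2.8-fold lower number from compound 1 to compound 4 (0.44 log units; beyond the scatter). The number for compound 2 is a limit: the limit of > 100000 nM in this assay, at which 1 of the 4 values shown sits.

Going by these compounds, whether the Z form also gives the lower number with pentyl or bromo in place of butyl remains open. So does the effect of an amine or a carboxylic acid on the aromatic ring.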